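Changing the Amine Substituent of Compound 2

A few compounds are considered here, and "the series" means these few. Any claim that something is new, unique, unknown or untested is made for them only; others in the source may bear on it.

In a functional assay on MCF7 cells (Homo sapiens) for antiproliferative activity (a lower number here means a stronger inhibitor, a higher number a weaker inhibitor), compound 1 (`CC(C)=CCc1cc(C(=O)Nc2cc3ccc(OCC4CCN(C)C4)c(C)c3oc2=O)ccc1O`) gives 1550 nM and compound 2 (`CC(C)=CCc1cc(C(=O)Nc2cc3ccc(OCCCNCCO)c(C)c3oc2=O)ccc1O`) gives 1560 nM as its value, level with compound 1 within the scatter. Compound 3 (`CC(C)=CCc1cc(C(=O)Nc2cc3ccc(OCCCN[C@H](C)c4ccccc4)c(C)c3oc2=O)ccc1O`) carries 1-phenylethyl in place of 2-hydroxyethyl on an amine nitrogen. Among the measured compounds shown here, the one measured step that bears on this is a swap of other groups (a 1.0-fold higher number from compound 1 to compound 2 (0.00 log units; within the scatter)) and it stayed within the scatter. For the measured compounds named here, with only that guide, the step expected in this assay also stays within the scatter (a 1.6-fold lower number from compound 2 to compound 3 (0.19 log units; within the scatter)). For compound 3 the estimated value is 1000 nM with an expected range of 350 nM to 3000 nM around it.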

Compound 3, half-maximal inhibitory concentration: 1450 nM
The estimate for compound 3 lay 1.5-fold (0.16 log units) below the measured number, and the stated range covers the measured number.
By their numbers in this assay, from the lowest: compounds 3, 1 and 2 (each within the scatter of the next).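

In this assay, the amine nitrogen accepts 1-phenylethyl, with its six-membered aromatic ring and defined stereocentre, in place of 2-hydroxyethyl, with a 1.1-fold lower number from compound 2 to compound 3 (0.03 log units; within the scatter). Swapping in 8 heavy atoms for 3, and losing the hydrogen-bond donor and acceptor of 2-hydroxyethyl, therefore leaves the number unmoved, and the comparison with compound 1 gives a 1.1-fold lower number from compound 1 to compound 3 (0.03 log units; within the scatter).

As far as these compounds go, whether the opposite stereocentre, a benzyl group or a carboxylic acid at this nitrogen would shift the number remains open. No measurement here explains why these numbers stay level.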